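Exchanging the dichlorophenyl ring in a hydrazone urea series

The source may report more compounds than this note shows. Statements on the series, on what has been measured and on what is new or still open speak of the compounds shown alone.

Compound 1 `CN(C)CCn1cnnc1-c1cc(Oc2ccc(NC(=O)N/N=C/c3cccc(Cl)c3Cl)cc2F)ccn1` was tested in a functional assay on NCI-H460 cells (Homo sapiens) for cytotoxicity, read by MTT assay, with a stated time of 72 h (on this read-out lower numbers stand for stronger inhibition and higher numbers for weaker inhibition), where compound 1 gives 72 nM, the lowest of the three numbers recorded so far. Compound 2 `COc1ccc(/C=N/NC(=O)Nc2ccc(Oc3ccnc(-c4nncn4CCN(C)C)c3)c(F)c2)c(OC)c1OC` gives 1790 nM, and compound 3 `CN(C)CCn1cnnc1-c1cc(Oc2ccc(NC(=O)N/N=C/c3ccc(F)cc3F)cc2F)ccn1` gives 1930 nM. Both changes away from compound 1 were large: a 25-fold higher number from compound 1 to compound 2 (1.40 log units; beyond the scatter) and a 27-fold higher number from compound 1 to compound 3 (1.43 log units; beyond the scatter), whereas a 1.1-fold higher number from compound 2 to compound 3 (0.03 log units; within the scatter) lies within the scatter. Compound 4 `COc1cc(/C=N/NC(=O)Nc2ccc(Oc3ccnc(-c4nncn4CCN(C)C)c3)c(F)c2)ccc1O` has not yet been measured. It differs from compound 1 in one place: 4-hydroxy-3-methoxyphenyl in place of 2,3-dichlorophenyl on a carbon with a double bond to nitrogen. The two measured steps that bear on this are the ones in which the 2,3-dichlorophenyl of compound 1 was exchanged for a differently substituted ring, and in both the number rose steeply and by a similar amount. Compound 4 is therefore expected to give a markedly higher number than compound 1, a step of about a 21-fold higher number from compound 1 to compound 4 (1.32 log units; beyond the scatter). The estimate for compound 4 is 1500 nM, with a range from 400 nM to 6000 nM.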

Compound 4, half-maximal inhibitory concentration: 57 nM
Compound 4: middle estimate off by 26-fold (1.42 log units), on the high side; measured number below the stated range.
By their numbers in this assay, from the lowest: compounds 4 and 1 (each within the scatter of the next); then compounds 2 and 3 (each within the scatter of the next).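

On the carbon with a double bond to nitrogen, the 2,3-dichlorophenyl of compound 1 can be replaced by 4-hydroxy-3-methoxyphenyl with no change beyond the scatter (a 1.3-fold lower number from compound 1 to compound 4 (0.10 log units; within the scatter)), so a steep rise on leaving that ring holds for compounds 2 and 3 but not for compound 4. In this assay, the ring exchange separates compound 4 sharply from the other two oxygen- or fluorine-bearing rings (a 34-fold lower number from compound 3 to compound 4 (1.53 log units; beyond the scatter); a 31-fold lower number from compound 2 to compound 4 (1.50 log units; beyond the scatter)), and a methoxy group alone does not decide the outcome, as compounds 2 and 4 both carry one. Nothing available bears on why these rings differ so widely.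

As far as these compounds go, it remains open whether the hydroxy or the methoxy group of compound 4 matters more. From the compounds shown here alone, how a 4-hydroxyphenyl ring, or a ring bearing an amine or a carboxylic acid, would behave at this place also remains open.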